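The source may report more compounds than this note shows. Statements on the series, on what has been measured and on what is new or still open speak of the compounds shown alone.

Working notes on the series.

The series is followed in an assay on isolated protein for inhibition of tyrosine-protein kinase receptor UFO (Homo sapiens), read by ELISA; a higher number here means a weaker inhibitor, a lower number a stronger inhibitor. Compound 1 `Cn1cc(-c2ccc(NC(=O)c3cn(CC4CCOCC4)cc(-c4ccc(Cl)cc4)c3=O)cc2)c2c(N)ncnc21` gives 0.2 nM in this assay. Compound 3 `Nc1ncnc2[nH]cc(-c3cc(F)c(NC(=O)c4cn(CC5CCOCC5)cc(-c5ccc(F)cc5)c4=O)cc3F)c12` gives 0.4 nM in this assay. Compound 2 `CC(C)n1cc(C(=O)Nc2cc(F)c(-c3c[nH]c4ncnc(N)c34)cc2F)c(=O)c(-c2ccc(F)cc2)c1` reaches only the limit of the assay, < 0.2 nM, and not a number; that is the floor described by the limit of < 0.2 nM in this assay, at which 1 of the 3 values shown sits. Compound 1 holds the lowest of the two numbers in hand, and its nearest neighbour is compound 3, which sits within the usual scatter of it. Going by the values given here, the only step measured in one place is an at least 2.0-fold higher number from compound 2 to compound 3 (0.30 log units; that floor lies within the scatter). It starts from a limit, and its floor lies within the scatter, so it tells little.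

Compound 4 `Cn1cc(-c2ccc(NC(=O)c3cn(CC4CCOCC4)cc(-c4ccccc4)c3=O)cc2)c2c(N)ncnc21` differs from compound 1 in hydrogen in place of chloro on an aromatic carbon. Among the compounds with values here, no measured step concerns a substituent on that ring: the single step in hand, from compound 2 to compound 3, changes the group on an aromatic nitrogen, and nothing varies the 4-chlorophenyl itself. The step from compound 1 to compound 4 is therefore expected to be small, a 2.0-fold higher number from compound 1 to compound 4 (0.30 log units; within the scatter), with a weaker inhibitor held as slightly more likely than a stronger one. Compound 4 is estimated at 0.4 nM in this assay, within 0.15 nM to 1.2 nM.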

Compound 4, half-maximal inhibitory concentration: 1 nM
The estimate for compound 4 lay 2.5-fold (0.40 log units) below the measured number, and the stated range covers the measured number.
By their numbers in this assay, from the lowest: compounds 1 and 3 (each within the scatter of the next); then compound 4.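

Going by these compounds alone, putting hydrogen in place of chloro gives a 5.0-fold higher number from compound 1 to compound 4 (0.70 log units; beyond the scatter) in this assay, and this is the only step in hand that lies beyond the scatter. Within the data shown here, the position para to a large group on this six-membered aromatic ring therefore registers in the read-out, whereas the one earlier step changed a group on an aromatic nitrogen and its floor lay within the scatter. Compound 2 gives a limit and not a number, and the number of the chloro compound stands at the same figure, so the printed size of this step may understate the true one: the limit of < 0.2 nM in this assay, at which 1 of the 4 values shown sits.

Going by these compounds, whether chloro itself matters, or any group at that place would serve, stays open: a methyl, a methoxy or a nitrile there would separate the two, and the 4-fluorophenyl of compound 2 and compound 3 gives no reading against compound 1, as those compounds differ from it in more than one place. On these data alone, how the change from 4-chlorophenyl to phenyl behaves with an isopropyl on the aromatic nitrogen also remains open.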